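The compounds below may be only part of what the source reports. "The series", "measured", "known", "first", "only" and "open" are said of these compounds alone.

In an ADME assay (intestine, Rattus norvegicus) for pharmacokinetics, using microsomes (a higher number here means that the compound lasts longer, a lower number that the compound disappears faster), compound 2 `CCOC(=O)/C=C/c1ccc(NC(=O)C2(NC(=O)c3ccc4c(C5CCCC5)c(-c5ncc(Cl)cn5)n(C)c4c3)CCC2)cc1OCC` gives > 5 h as a limit of the assay, not a number. Compound 3 `CCOc1cc(NC(=O)C2(NC(=O)c3ccc4c(C5CCCC5)c(-c5ncc(Cl)cn5)n(C)c4c3)CCC2)ccc1/C=C/C(=O)OCC(C)C` gives > 5 h as a limit too. Going by the values given here, the set as a whole shows the limit of > 5 h in this assay, at which 2 of the 3 values shown sit, and so leaves only one true number. That number belongs to compound 1 `CCOc1cc(NC(=O)C2(NC(=O)c3ccc4c(C5CCCC5)c(-c5ncc(Cl)cn5)n(C)c4c3)CCC2)ccc1/C=C/C(=O)OCOP(=O)(O)O`, which gives 0.0833 h in this assay as a measured half-life.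

Compound 4 `CCOc1cc(NC(=O)C2(NC(=O)c3ccc4c(C5CCCC5)c(-c5ncc(Cl)cn5)n(C)c4c3)CCC2)ccc1/C=C/C(=O)OCc1ccccc1` differs from compound 2 by phenyl in place of methyl on a saturated chain carbon bound to an oxygen next to a carbonyl group. Among the compounds with values here, all the measured steps act at that same place. The large steps of an at least 60-fold higher number from compound 1 to compound 2 (1.77 log units; beyond the scatter) and an at least 60-fold higher number from compound 1 to compound 3 (1.77 log units; beyond the scatter) remove a group holding phosphorus, so they give no size for an exchange of one carbon-only group for another. The nearest match is a step that the two limits leave unreadable from compound 2 to compound 3, with isopropyl in place of methyl, and it has no readable size. Within the data shown here, no measured step therefore sizes the phenyl change directly.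

With that gap in mind, no step beyond the scatter is expected in this assay, and a reading at the limit is likely. The estimated outcome is a number no higher from compound 2 to compound 4 (the limit leaves the size open), with no clear direction expected. For compound 4 the expected value is 5 h, within an estimated range from 2 h to 10 h for now.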

Compound 4, half-life: > 5 h
Compound 4: only a limit was reported; the forecaster's own chance of this, stated with the estimate: 60%; the middle value sits exactly at the limit.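

In this assay, phenyl at the saturated chain carbon bound to an oxygen next to a carbonyl group adds a six-membered aromatic ring to the groups seen at this place, and an at least 60-fold higher number from compound 1 to compound 4 (1.77 log units; beyond the scatter) shows that this ring does not bring the short half-life of compound 1 back. The steps from compound 2 to compound 4 and from compound 3 to compound 4 cannot be read, as both ends of each step are limits. Methyl, isopropyl and phenyl at this place therefore all end at the same ceiling, while only compound 1, with its phosphorus-holding group, gives a true number: the limit of > 5 h in this assay, at which 3 of the 4 values shown sit.

From the compounds shown here alone, how far compound 2, compound 3 and compound 4 lie past that ceiling stays open, so no order among the ethyl, benzyl and other carbon-only esters can be given. Also open, going by these compounds, is how this assay would read for a carboxylic acid in place of the ester, or for a chain ending in an amine at this place.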